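Benzothiazole thioacetamide series: azido-to-nitro step

A few compounds are considered here, and "the series" means these few. Any claim that something is new, unique, unknown or untested is made for them only; others in the source may bear on it.

Measured compounds:
Compound 1 `COc1cc(N(Cc2ccc(Br)cc2)C(=O)CSc2nc3ccccc3s2)cc(OC)c1OC` gives 48100 nM.
Compound 2 `COc1ccc(CN(C(=O)CSc2nc3ccccc3s2)c2cc(OC)c(OC)c(OC)c2)cc1C(F)(F)F` gives 25200 nM.
Compound 3 `COc1ccc(CN(C(=O)CSc2nc3ccccc3s2)c2cc(OC)c(OC)c(OC)c2)cc1N=[N+]=[N-]` gives 187 nM.

In a functional assay on MGC-803 cells (Homo sapiens) for antiproliferative activity, read by MTT assay, with a stated time of 48 h (on this read-out higher numbers stand for weaker inhibition and lower numbers for stronger inhibition), compound 3 stands lowest of the three, with a 260-fold lower number from compound 1 to compound 3 (2.41 log units; beyond the scatter) and a 130-fold lower number from compound 2 to compound 3 (2.13 log units; beyond the scatter), while a 1.9-fold lower number from compound 1 to compound 2 (0.28 log units; within the scatter). Compound 4 `COc1ccc(CN(C(=O)CSc2nc3ccccc3s2)c2cc(OC)c(OC)c(OC)c2)cc1[N+](=O)[O-]` differs from compound 3 by nitro in place of azido on an aromatic carbon. Within the data shown here, both large steps toward compound 3 rest on the azido group arriving; no measured pair shows azido against nitro, so there is no direct guide. Since both other substituents at this position sit far higher than compound 3, the expected step of a 13-fold higher number from compound 3 to compound 4 (1.13 log units; beyond the scatter) is upward, but its size is uncertain. Compound 4 is estimated at 2500 nM, within 250 nM to 25000 nM.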

Compound 4, half-maximal inhibitory concentration: 682 nM
Beside the measured number, compound 4's estimate is 3.7-fold (0.56 log units) above it; the measured number falls inside the stated range.
By their numbers in this assay, from the lowest: compound 3; then compound 4; then compounds 2 and 1 (each within the scatter of the next).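

In this assay azido is not alone at this position, ortho to a methoxy group, in giving a low number: nitro in place of trifluoromethyl gives a 37-fold lower number from compound 2 to compound 4 (1.57 log units; beyond the scatter) and 4-methoxy-3-nitrophenyl in place of 4-bromophenyl gives a 71-fold lower number from compound 1 to compound 4 (1.85 log units; beyond the scatter). Azido still stays ahead of nitro, with a 3.6-fold higher number from compound 3 to compound 4 (0.56 log units; beyond the scatter) and that step lies beyond the scatter. Nothing at hand accounts for this order of groups.

Open, going by these compounds, is whether an amine or a nitrile at this position would fall nearer azido or nitro. Also open, on these data alone, is whether the order of azido and nitro holds with a hydroxyl in place of the methoxy group.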